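Pyrazoline thiocarboxamides: aryl swap at the imine carbon

The source may hold more compounds than are shown below. What is called first, only, known or untested is meant among the compounds shown, and "the series" means these compounds.

Working notes on the series. Compound 1 `S=C(Nc1ccccc1)N1N=C(c2ccc(Br)cc2)CC1c1ccc2c(c1)OCCO2` gives 870 nM in a functional assay on WM 266-4 cells (Homo sapiens) for antiproliferative activity, read by MTT assay, with a stated time of 48 h; on this read-out lower numbers stand for stronger inhibition of growth and higher numbers for weaker inhibition of growth. Compound 2 `FC(F)(F)c1ccc(C2=NN(C(=S)Nc3ccccc3)C(c3ccc4c(c3)OCCO4)C2)cc1` gives 52400 nM, and compound 3 `O=[N+]([O-])c1ccc(C2=NN(C(=S)Nc3ccccc3)C(c3ccc4c(c3)OCCO4)C2)cc1` gives 105000 nM, the highest number among the three measured compounds. The step of a 120-fold higher number from compound 1 to compound 3 (2.08 log units; beyond the scatter) is large, as is a 60-fold higher number from compound 1 to compound 2 (1.78 log units; beyond the scatter); by contrast a 2.0-fold higher number from compound 2 to compound 3 (0.30 log units; within the scatter) stays within the scatter, so compound 2 and compound 3 cannot be ordered.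

Compound 4 `COc1ccccc1C1=NN(C(=S)Nc2ccccc2)C(c2ccc3c(c2)OCCO3)C1` is the next member: 2-methoxyphenyl in place of 4-nitrophenyl on a carbon with a double bond to nitrogen. For the measured compounds named here, no measured step touches a methoxy group, and no measured compound carries its substituent anywhere but where bromo, trifluoromethyl and nitro sit, so the change is only loosely covered. What bears on it is that compound 3, carrying the nitro group, stands at the top, and that the step from compound 1 to compound 3 is large. Removing the nitro group is therefore expected to bring the number down, though by an uncertain amount; the estimated step is a 5.3-fold lower number from compound 3 to compound 4 (0.72 log units; beyond the scatter). For compound 4 the expected value in this assay is 20000 nM, with a range from 3000 nM to 120000 nM.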

Compound 4, concentration for 50% growth inhibition: 25800 nM
For compound 4 the middle estimate is 1.3-fold (0.11 log units) below the measured one; measured number inside the range.
By their numbers in this assay, from the lowest: compound 1; then compound 4; then compounds 2 and 3 (each within the scatter of the next).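

The 2-methoxyphenyl group at this carbon gives a number separable from both electron-poor-free comparisons: the step to compound 4 from the nitro analogue is beyond the scatter (a 4.1-fold lower number from compound 3 to compound 4 (0.61 log units; beyond the scatter)), as is the step from the trifluoromethyl analogue (a 2.0-fold lower number from compound 2 to compound 4 (0.31 log units; beyond the scatter)), whereas compound 2 and compound 3 could not be ordered. Even so, the 2-methoxyphenyl group stays far from the 4-bromophenyl group (a 30-fold higher number from compound 1 to compound 4 (1.47 log units; beyond the scatter)), so among the four aryl groups at this position only compound 1 reaches a low number. No measurement on hand accounts for these gaps.

Compound 4 changes both the group and its place on the aryl ring, so the shown compounds cannot separate the methoxy group itself from where it sits. Also open, on these data alone, is how an amine, a carboxylic acid or a longer alkoxy chain on this ring would compare with the bromo group of compound 1.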